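The source may report more compounds than this note shows. Statements on the series, on what has been measured and on what is new or still open speak of the compounds shown alone.

Of the compounds shown here, two sharing one core have been tested so far in an ADME assay on L929 cells (Mus musculus) for cytotoxicity, read by resazurin assay, with a stated time of 72 h; a higher number here means a weaker inhibitor, a lower number a stronger inhibitor. Compound 1 `O=C(NC1CCCCC1)c1cccn1-c1ccc2c(c1)B(O)OC2` carries an amide on that core. In this assay compound 1 gives > 10 ug/mL, which is a limit of the assay rather than a number. Compound 2 `CCc1ccc(C(=O)c2ccn(-c3ccc4c(c3)B(O)OC4)c2)cc1` carries a ketone instead. In this assay compound 2 gives > 10 ug/mL, again a limit and not a number. Among the compounds with values here, compound 2 therefore stands exactly where every value so far stands: the limit of > 10 ug/mL in this assay, at which 2 of the 2 values shown sit. Both readings are limits. Within the data shown here, no step between the measured compounds can be sized.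

The next compound, compound 3 `Cc1ccsc1C(=O)c1ccn(-c2ccc3c(c2)B(O)OC3)c1`, differs from compound 2 in one place: 3-methylthiophen-2-yl in place of 4-ethylphenyl on a carbonyl carbon. The carbonyl and the core remain untouched.

Because compound 2 and compound 1 both sit at the limit of > 10 ug/mL in this assay, at which 2 of the 2 values shown sit, the step expected in this assay is a step that the limit leaves unreadable from compound 2 to compound 3, that is, none beyond the usual scatter. Compound 3 is expected to give about 15 ug/mL, with a range from 8 ug/mL to 40 ug/mL, and most likely the assay will again report only a limit.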

Compound 3, half-maximal inhibitory concentration: > 10 ug/mL
Compound 3: no number, only a limit; the forecaster's own chance of this, stated with the estimate: 85%; the middle value does not contradict the limit.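

Within the data shown here, compound 2 and compound 3 each give only a limit in this assay, so no step between them can be read, and 3-methylthiophen-2-yl in place of 4-ethylphenyl cannot be sized. All the readings shown share one limit: the limit of > 10 ug/mL in this assay, at which 3 of the 3 values shown sit.

The compounds shown leave open at what concentration any of them would reach half-maximal inhibition, and whether they differ from one another at all.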